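The source may report more compounds than this note shows. Statements on the series, on what has been measured and on what is new or still open speak of the compounds shown alone.

Two compounds measured so far in an ADME assay on HEK293 cells (Homo sapiens) for cytotoxicity, with a stated time of 72 h; a lower number here means that less compound is needed, a higher number that more compound is needed for the effect 

- compound 1 (`Cc1cc(NC(=O)Nc2ccc(SC(F)(F)F)cc2)c2ccccc2n1`) gives 13000 nM 
- compound 2 (`Cc1cc(NC(=O)Nc2cccnc2)c2ccccc2n1`) gives > 25000 nM as a limit

Compound 2 stands at the limit of > 25000 nM in this assay, at which 1 of the 2 values shown sits, and this entry is a limit, not a number. Among the measured compounds shown here, only compound 1 gives a true number, and no pair of measured compounds differs in just one place, so no measured step is available as a guide.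

Compound 3 (`Cc1cc(NC(=O)Nc2ccc(N)cc2)c2ccccc2n1`) carries 4-aminophenyl in place of pyridin-3-yl on an amide-type nitrogen, and otherwise matches compound 2. The change in full reads (4-aminophenyl in place of pyridin-3-yl on an amide-type nitrogen) and it is the only one.

For the measured compounds named here, with compound 1 at 13000 nM as the sole true number, compound 3 is expected to need a similarly high concentration in this assay and not a much lower one. The expected size of the change is an at least 1.1-fold lower number from compound 2 to compound 3 (0.05 log units; that floor lies within the scatter) and this estimate lies within the scatter, with no firm direction. For compound 3 the estimate is 22000 nM with an expected range from 9000 nM to 50000 nM and a real chance of a limit once more.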

Compound 3, half-maximal effective concentration: > 25000 nM
Compound 3 gave a limit, no number; the forecaster's own chance of this, stated with the estimate: 55%; at least 1.1-fold (0.05 log units) between middle value and limit.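

In this assay, among the compounds shown here, amino in place of (trifluoromethyl)sulfanyl on an aromatic carbon gives the only step that can be read here: an at least 1.9-fold higher number from compound 1 to compound 3 (0.28 log units; that floor lies within the scatter). This figure is only a minimum, so the true gap could be larger, but the part that is secured does not go beyond the usual scatter of the assay, and so it does not yet show that this change has a real effect. The step from compound 2 to compound 3 cannot be read, so 4-aminophenyl and pyridin-3-yl on the amide-type nitrogen cannot be ranked against each other, and compound 1 remains the only compound with a true number: the limit of > 25000 nM in this assay, at which 2 of the 3 values shown sit.

On these data alone, how far compound 2 and compound 3 each lie beyond their limit stays open, and so does the size of any difference between them. As far as these compounds go, it also remains open whether a smaller group such as chlorine or a carboxylic acid, in place of amino on the same aromatic carbon, would give a true number and so show how this position behaves.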